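Replacing 3-nitrophenyl with 4-fluorophenyl in compound 1

A few compounds are considered here, and "the series" means these few. Any claim that something is new, unique, unknown or untested is made for them only; others in the source may bear on it.

- Compound 1 `O=C(Nc1cccc([N+](=O)[O-])c1)N1CCN(S(=O)(=O)c2sccc2-c2ccccc2Oc2ccc(O)c(O)c2)CC1`: > 20000 nM (a limit)
- Compound 2 `COc1ccc(Oc2ccccc2-c2ccsc2S(=O)(=O)N2CCN(C(=O)Nc3cccc([N+](=O)[O-])c3)CC2)cc1OC`: > 50000 nM (a limit)

In a functional assay on HeLa cells (Homo sapiens) for inhibition, read by CCK-8 assay, with a stated time of 48 h (a higher number here means a weaker inhibitor, a lower number a stronger inhibitor), compound 1 stands at > 20000 nM, which is a limit and not a number. Compound 3 `O=C(Nc1ccc(F)cc1)N1CCN(S(=O)(=O)c2sccc2-c2ccccc2Oc2ccc(O)c(O)c2)CC1` carries 4-fluorophenyl in place of 3-nitrophenyl on an amide-type nitrogen. Going by the values given here, the only measured step, a step that the two limits leave unreadable from compound 1 to compound 2, concerns 3,4-dimethoxyphenyl in place of 3,4-dihydroxyphenyl, a different change, so it offers no size to carry over and no direction is expected with confidence. The expected change is a number no higher from compound 1 to compound 3 (the limit leaves the size open). Compound 3 is estimated at 20000 nM, with an expected range of 5000 nM to 60000 nM.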

Compound 3, half-maximal inhibitory concentration: 14800 nM
The estimate for compound 3 lay 1.4-fold (0.13 log units) above the measured number, within the range that was stated.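

In this assay compound 3 gives 14800 nM, the first value among these compounds that is a number and not a limit. Compound 1 is held at a limit of the assay: the limit of > 20000 nM in this assay, at which 1 of the 3 values shown sits.

Putting 4-fluorophenyl in place of 3-nitrophenyl on the amide-type nitrogen gives an at least 1.3-fold lower number from compound 1 to compound 3 (0.13 log units; that floor lies within the scatter), and how far the true step exceeds that floor cannot be read. As far as these compounds go, whether an amine or a carboxylic acid in place of the fluorine would shift the number stays open, as does the effect of 3,4-dimethoxyphenyl when 4-fluorophenyl is present.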